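The compounds below may be only part of what the source reports. "The series", "measured", "known", "first", "only" and "open" are said of these compounds alone.

Among the compounds with values here, compound 1 `C[C@]1(O)CC(=O)OC(CSc2nc(-c3ccccc3)c(-c3ccccc3)[nH]2)C1` is one of two compounds measured in an assay on microsomes from liver for inhibition of sterol O-acyltransferase 1 (Rattus norvegicus) (a higher number here means a weaker inhibitor, a lower number a stronger inhibitor), and in this assay compound 1 gives 140 nM. Compound 2 `C[C@@]1(O)CC(=O)OC(CSc2nc(-c3cccc(Cl)c3)c(-c3cccc(Cl)c3)[nH]2)C1` gives 110 nM, and the two values lie within the usual scatter of each other. Compound 3 `c1ccc(-c2nc(SCCC3OCCCO3)[nH]c2-c2ccccc2)cc1` has not yet been measured; it differs from compound 1 by a group of 7 heavy atoms (5 carbon, 2 oxygen; one six-membered non-aromatic ring with 2 hetero atoms) in place of a group of 9 heavy atoms (6 carbon, 3 oxygen; one six-membered non-aromatic ring with 1 hetero atom), on a saturated chain carbon bound to a sulfur. Within the data shown here, no step between measured compounds shows what such a change does here. The step of a 1.8-fold higher number from compound 1 to compound 3 (0.25 log units; within the scatter) is expected to be small, toward a weaker inhibitor, and may still fall within the scatter. Compound 3 is expected to give 250 nM, with a range from 80 nM to 800 nM.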

Compound 3, half-maximal inhibitory concentration: 730 nM
Beside the measured number, compound 3's estimate is 2.9-fold (0.47 log units) below it; the measured number falls inside the stated range.
By their numbers in this assay, from the lowest: compounds 2 and 1 (each within the scatter of the next); then compound 3.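

In this assay this position is sensitive to the group it carries: putting the group of 7 heavy atoms on the saturated chain carbon bound to a sulfur gives a step beyond the scatter (a 5.2-fold higher number from compound 1 to compound 3 (0.72 log units; beyond the scatter)). The change removes the hydrogen-bond donor and the double bond outside aromatic rings together, so this single step cannot separate their contributions, and no measurement here explains the loss. Going by these compounds, whether a hydroxyl or a carbonyl on the entering ring would recover the lower number remains open, as does the outcome with an amine or a carboxylic acid at this place.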